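A few compounds are considered here, and "the series" means these few. Any claim that something is new, unique, unknown or untested is made for them only; others in the source may bear on it.

In a physicochemical assay for lipophilicity, at pH 7.4 (on this read-out lower numbers stand for lower lipophilicity and higher numbers for higher lipophilicity), compound 1 `CCc1ccc(N(CC(C)C)S(=O)(=O)c2ccc3c(c2)C(O)CC(C2CCN(S(C)(=O)=O)CC2)O3)cc1` gives 3.22, the lower of the two numbers available, while compound 2 `CCc1ccc(N(CC(C)C)S(=O)(=O)c2ccc3c(c2)CCC(C2CCOCC2)O3)cc1` gives 5.38, clearly higher. Compound 3 `CCc1ccc(N(CC(C)C)S(=O)(=O)c2ccc3c(c2)C(O)CC(C2CCNCC2)O3)cc1` has not yet been measured. It differs from compound 1 in one place, with hydrogen in place of methylsulfonyl on an amine nitrogen in a ring. Among the compounds with values here, no measured pair shows this exchange, so the expectation rests on the structural change alone. In this assay, a modest fall, slightly beyond the scatter, is expected: a number 0.52 log units lower from compound 1 to compound 3 (beyond the scatter). The estimate for compound 3 is 2.7, with a range of 1.9 to 3.5.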

Compound 3, distribution coefficient: 1.04
Compound 3: middle estimate off by 1.66 log units, on the high side; the measured number lies below the stated range.
By their numbers in this assay, from the lowest: compound 3; then compound 1; then compound 2.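

Within the data shown here, replacing 1-(methylsulfonyl)piperidin-4-yl with piperidin-4-yl gives, in this assay, a number 2.18 log units lower from compound 1 to compound 3 (beyond the scatter) and is the first measured example of this exchange. On the core of compound 1, what sits on this one ring nitrogen therefore has a large effect on the read-out. Nothing measured here explains the size of this step.

The compounds shown leave open where a methyl or an acetyl group on this nitrogen would fall relative to compound 1 and compound 3. They also leave open whether the same exchange gives a step of similar size on a core without the hydroxyl group.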